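A few compounds are considered here, and "the series" means these few. Any claim that something is new, unique, unknown or untested is made for them only; others in the source may bear on it.

Measured so far in a functional assay on MCF7 cells (Homo sapiens) for cytotoxicity; on this read-out lower numbers stand for stronger inhibition and higher numbers for weaker inhibition:
compound 1 `N#C/N=C1\N(CCCCCOc2ccc(Cl)cc2)C(=O)CN1c1ccncc1` gives 5360 nM;
compound 2 `N#C/N=C1\N(CCCCCCOc2ccc(Cl)cc2)C(=O)CN1c1ccncc1` gives 443 nM;
compound 3 `CC1C(=O)N(CCCCCCOc2ccc(Cl)cc2)/C(=N\C#N)N1c1ccncc1` gives 270 nM.

The step from compound 1 to compound 2 is (4-chlorophenoxy)methyl in place of 4-chlorophenoxy on a saturated chain carbon, five bonds along the chain from an amide-type nitrogen in a ring, and it reads a 12-fold lower number from compound 1 to compound 2 (1.08 log units; beyond the scatter). From compound 2 to compound 3 the step is a 1.6-fold lower number from compound 2 to compound 3 (0.22 log units; within the scatter). Compound 3 holds the lowest number of the three, but its gap to compound 2 lies within the scatter.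

Compound 4 `CC1C(=O)N(CCCCCCCOc2ccc(Cl)cc2)/C(=N\C#N)N1c1ccncc1` is not yet measured. It differs from compound 3 by (4-chlorophenoxy)methyl in place of 4-chlorophenoxy on a saturated chain carbon, six bonds along the chain from an amide-type nitrogen in a ring. This is the same kind of change as that from compound 1 to compound 2, not the same: there the place was five bonds along the chain from the amide-type nitrogen in the ring, here it is six. The difference between the cores of compound 1 and compound 3 is not broken down here.

For compound 4 in this assay the expected step is a 1.4-fold lower number from compound 3 to compound 4 (0.13 log units; within the scatter), smaller than the measured one, because a 12-fold lower number from compound 1 to compound 2 (1.08 log units; beyond the scatter) rests on a single pair and need not repeat at the new place. Compound 4 is estimated at 200 nM, with a likely range from 60 nM to 700 nM.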

Compound 4, half-maximal inhibitory concentration: 460 nM
Compound 4: the middle estimate sits 2.3-fold (0.36 log units) below what was measured, and the stated range covers the measured number.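

In this assay, putting (4-chlorophenoxy)methyl in place of 4-chlorophenoxy gives a 1.7-fold higher number from compound 3 to compound 4 (0.23 log units; within the scatter), so on the core of compound 3 this change shows no step beyond the scatter. The change therefore does not carry over as a fixed increment between these two cores: the same change on two cores in this assay, a 12-fold lower number (1.08 log units; beyond the scatter) from compound 1 to compound 2 and a 1.7-fold higher number (0.23 log units; within the scatter) from compound 3 to compound 4, 21-fold (1.31 log units) apart, beyond the scatter of two such steps This does not show that the core alone decides the outcome, since the change sits five bonds along the chain in one pair and six in the other, and each reading rests on a single pair.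

Open, going by these compounds, is how the core of compound 3 behaves with the shorter chain of compound 1, which would put the change at the same place on both cores. Also open, on these data alone, is what a longer chain than that of compound 4 gives.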